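The source may hold more compounds than are shown below. What is called first, only, known or untested is meant among the compounds shown, and "the series" means these compounds.

Measured in an ADME assay on L02 cells (Homo sapiens) for cytotoxicity, read by MTT assay, with a stated time of 24 h; on this read-out higher numbers stand for weaker inhibition and lower numbers for stronger inhibition:
- Compound 1 `CC(=O)Nc1ccc(S(=O)(=O)N2C/C(=C\c3cccnc3)C(=O)/C(=C/c3ccccc3F)C2)cc1`: 15600 nM
- Compound 2 `O=C1/C(=C/c2cccnc2)CN(S(=O)(=O)c2ccc(C(F)(F)F)cc2)C/C1=C\c1ccccc1C(F)(F)F`: 14300 nM
- Compound 3 `O=C1/C(=C/c2cccnc2)CN(S(=O)(=O)c2ccc(Cl)cc2)C/C1=C\c1ccccc1C(F)(F)F`: 11900 nM

Compound 3, at 11900 nM, is not separated from the other two compounds: all three values lie within the scatter of one another. Within the data shown here, the series so far therefore shows a flat read-out, with no clear ranking among its members.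

The next compound to be read is compound 4 `CC(=O)Nc1ccc(S(=O)(=O)N2C/C(=C\c3cccnc3)C(=O)/C(=C/c3ccccc3C(F)(F)F)C2)cc1`, which differs from compound 3 at one place: acetamido in place of chloro on an aromatic carbon. In words, this is acetamido in place of chloro on an aromatic carbon, or 4-chlorophenyl to 4-acetamidophenyl.

Among the measured compounds shown here, no measured step makes this exact change. For the measured compounds named here, the one measured step, a 1.2-fold lower number from compound 2 to compound 3 (0.08 log units; within the scatter), concerns the same aromatic carbon but exchanges different groups, and it stays small. Compound 1 carries the same 4-acetamidophenyl group and gives 15600 nM in this assay, although it has fluoro where compound 4 has trifluoromethyl. Going by the values given here, neither observation points to a change beyond the scatter, so no step of that size is expected, and no direction can be assigned with confidence.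

The estimated step is a 1.2-fold higher number from compound 3 to compound 4 (0.07 log units; within the scatter) and is expected to remain within the scatter.

For compound 4 the expected value is 14000 nM, with an estimated range from 8000 nM to 24000 nM in this assay.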

Compound 4, half-maximal inhibitory concentration: 15300 nM
The estimate for compound 4 lay 1.1-fold (0.04 log units) below the measured number; low and high end bracket the measured number.
By their numbers in this assay, from the lowest: compounds 3, 2, 4 and 1 (each within the scatter of the next).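

In this assay, the aromatic carbon para to a large group now carries three groups with no separation among them: a 1.3-fold higher number from compound 3 to compound 4 (0.11 log units; within the scatter) for acetamido in place of chloro, and a 1.1-fold higher number from compound 2 to compound 4 (0.03 log units; within the scatter) for acetamido in place of trifluoromethyl. Acetamido enters with four heavy atoms, a hydrogen-bond donor and a hydrogen-bond acceptor, so this position tolerates a group of a different size and count from chloro and trifluoromethyl without leaving the scatter in this assay. Among these compounds, the pair with acetamido held constant adds a first reading at the other substituted aromatic carbon, where a 1.0-fold lower number from compound 1 to compound 4 (0.01 log units; within the scatter) for trifluoromethyl in place of fluoro also stays within the scatter, and no measured evidence bears on why these values sit so close.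

On these data alone, whether an amine or a carboxylic acid in place of acetamido would give a step beyond the scatter stays open. The compounds shown also leave open whether a longer chain at this position, or a methoxy group in place of fluoro or trifluoromethyl, would separate from the four values read so far.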